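The compounds below may be only part of what the source reports. "The series", "measured", "known", "first", "only" and "open" are said of these compounds alone.

Measured in a functional assay on A549 cells (Homo sapiens) for inhibition, read by sulforhodamine B assay, with a stated time of 72 h; on this read-out higher numbers stand for weaker inhibition and lower numbers for stronger inhibition:

Compound 1 `CC1CCN(C(=O)c2c(N)sc(-c3ccc(Cl)cc3)c2-c2ccc(Cl)cc2)CC1` gives 1750 nM
Compound 2 `CCOC(=O)Nc1sc(-c2ccc(Cl)cc2)c(-c2ccc(Cl)cc2)c1C(=O)NC1CC1` gives 39800 nM
Compound 3 `CC(C)(C)NC(=O)c1c(N)sc(-c2ccc(Cl)cc2)c1-c1ccc(Cl)cc1` gives 8850 nM

Of these three numbers, compound 1 has the lowest (1750 nM), which makes it the strongest inhibitor of the set. Its nearest neighbour is compound 3 (8850 nM), and furthest away lies compound 2 (39800 nM).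

Compound 4 `CC(C)CNC(=O)c1c(N)sc(-c2ccc(Cl)cc2)c1-c1ccc(Cl)cc1` has not yet been measured. Its structure departs from compound 1 in one place, (isobutylamino in place of 4-methylpiperidin-1-yl on a carbonyl carbon), with isobutylamino in place of 4-methylpiperidin-1-yl on a carbonyl carbon.

For the measured compounds named here, only one measured step bears directly on this change. It is a 5.1-fold higher number from compound 1 to compound 3 (0.70 log units; beyond the scatter), in which (tert-butyl)amino takes the place of the same 4-methylpiperidin-1-yl on the carbonyl carbon. Like isobutylamino, (tert-butyl)amino has no ring. Going by the values given here, a single step is thin support, and the data hold no measured compound carrying isobutylamino itself. Even so, a modest step toward a higher number, beyond the scatter and of similar size, is expected in this assay. The estimated step is a 3.4-fold higher number from compound 1 to compound 4 (0.54 log units; beyond the scatter), a rise that remains an expectation. For compound 4 the estimated value is 6000 nM, with an expected range from 2500 nM to 15000 nM.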

Compound 4, half-maximal inhibitory concentration: 21000 nM
Compound 4: the middle estimate sits 3.5-fold (0.54 log units) below what was measured, and the stated range ends below it.
By their numbers in this assay, from the lowest: compound 1; then compound 3; then compounds 4 and 2 (each within the scatter of the next).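

In this assay, isobutylamino on the carbonyl carbon gives a large step (a 12-fold higher number from compound 1 to compound 4 (1.08 log units; beyond the scatter)), which goes further than the modest step seen with (tert-butyl)amino (a 5.1-fold higher number from compound 1 to compound 3 (0.70 log units; beyond the scatter)). The two groups without a ring are therefore not interchangeable at this position, since exchanging tert-butyl for isobutyl on the amide-type nitrogen also moves the number beyond the scatter (a 2.4-fold higher number from compound 3 to compound 4 (0.38 log units; beyond the scatter)), so the size of the step depends on which group enters as well as on the 4-methylpiperidin-1-yl that leaves. No measurement given here explains this difference between the groups.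

Going by these compounds, it remains open whether the low number of compound 1 goes with the ring or with its methyl group, a question that piperidin-1-yl without the methyl, pyrrolidin-1-yl or morpholin-4-yl on the same carbonyl carbon could address. Also open, on these data alone, is where a straight butylamino chain would fall relative to compound 3 and compound 4, and whether diethylamino, which has no ring and no amide hydrogen, would stand closer to compound 1 or to these two amides.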